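The source may hold more compounds than are shown below. What is called first, only, known or untested is meant among the compounds shown, and "the series" means these compounds.

Compound 2 `CCC(C)(C)Cc1c[nH]c(CCc2ccc(-c3cnsc3)cc2)n1` gives 6.9 nM in a functional assay on HEK293 cells for agonist activity at Bombesin receptor subtype-3 (Mus musculus), read by luminescence and calcium flux, with a stated time of 10 min; a higher number here means that more compound is needed for the effect, a lower number that less compound is needed. Among the two numbers recorded in this assay it is the larger one, yet the step of a 1.8-fold higher number from compound 1 to compound 2 (0.25 log units; within the scatter) leaves compound 1 `CCC(C)(C)Cc1c[nH]c(CCc2ccc(-c3cccc(N)n3)cc2)n1`, at 3.9 nM, indistinguishable from it. Compound 3 `CCC(C)(C)Cc1c[nH]c(CCc2ccc(-n3cncn3)cc2)n1` is the next entry in the series: 1H-1,2,4-triazol-1-yl in place of 1,2-thiazol-4-yl on an aromatic carbon. Going by the values given here, only one measured step bears on this position, the exchange of one aromatic ring for another five-membered aromatic ring at the same carbon, and that step, a 1.8-fold higher number from compound 1 to compound 2 (0.25 log units; within the scatter), stayed inside the scatter. With the shared core and the rest of the molecule unchanged, the exchange for another small aromatic ring is expected to give no step beyond the scatter in this assay, in either direction. The expected step is a 1.0-fold higher number from compound 2 to compound 3 (0.01 log units; within the scatter). Compound 3 is therefore estimated at 7 nM, with a range from 2.5 nM to 20 nM.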

Compound 3, half-maximal effective concentration: 12 nM
Beside the measured number, compound 3's estimate is 1.7-fold (0.23 log units) below it; low and high end bracket the measured number.
By their numbers in this assay, from the lowest: compounds 1, 2 and 3 (each within the scatter of the next, the first and the last beyond it).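

In this assay, 1H-1,2,4-triazol-1-yl in place of 1,2-thiazol-4-yl gives a 1.7-fold higher number from compound 2 to compound 3 (0.24 log units; within the scatter), so the exchange between these two five-membered aromatic rings cannot be separated at this position. Going by these compounds alone, the first step beyond the scatter at this carbon appears only across the full span of the series: 1H-1,2,4-triazol-1-yl in place of 6-aminopyridin-2-yl gives a 3.1-fold higher number from compound 1 to compound 3 (0.49 log units; beyond the scatter), a modest step, and compound 2 lies within the scatter of both ends. Nothing measured on these compounds accounts for that gap.

Going by these compounds, whether the amine on the six-membered ring of compound 1 contributes to this gap stays open, and an unsubstituted pyridin-2-yl at the same carbon would test it. Also open, on these data alone, is how a carboxylic acid at this carbon, or a shorter alkyl chain on the shared core, would behave.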